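The source may report more compounds than this note shows. Statements on the series, on what has been measured and on what is new or still open speak of the compounds shown alone.

Of the compounds shown here, three with a shared core have been measured in an assay for binding affinity to adenosine receptor A1 (Bos taurus); a higher number here means a weaker inhibitor, a lower number a stronger inhibitor. Compound 1 `CCn1c(=O)c2nc(-c3ccc(S(=O)(=O)N4CCOCC4)cc3)[nH]c2n(CC)c1=O` gives 13 nM in this assay. Compound 2 `CN(C)c1cccc(-c2nc3c(=O)n(C)c(=O)n(C)c3[nH]2)c1` gives 80 nM in this assay, and compound 3 `CCn1c(=O)c2nc(-c3ccc(Cl)cc3N)[nH]c2n(CC)c1=O` gives 0.8 nM in this assay. Among these three numbers, compound 1 stands second highest: its nearest neighbour is compound 2, whose number is higher by a margin beyond the usual scatter, and its furthest is compound 3, whose number is lower by a margin also beyond the scatter. Going by the values given here, no pair of the measured compounds differs in only one place, so the measured values show no isolated single change.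

The unmeasured compound 4 `CCn1c(=O)c2nc(-c3ccc(S(=O)(=O)NCC(C)O)cc3)[nH]c2n(CC)c1=O` is related to compound 1 by one change: (2-hydroxypropyl)amino in place of morpholin-4-yl on a sulfonyl sulfur. The difference lies only in what the sulfonyl sulfur bears; its other neighbour, the aromatic carbon, is unchanged. Among the compounds with values here, no measured pair shows a change of this kind, so the size of the step rests on judgement alone. The step is expected to be small, if anything toward a slightly higher number, with a real chance that it stays within the scatter. Compound 4 is therefore estimated at 20 nM in this assay, within a range of 5 nM to 80 nM. That estimate means a step of a 1.5-fold higher number from compound 1 to compound 4 (0.19 log units; within the scatter) is expected.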

Compound 4, half-maximal inhibitory concentration: 4.2 nM
For compound 4 the middle estimate is 4.8-fold (0.68 log units) above the measured one; measured number below the stated range.
By their numbers in this assay, from the lowest: compound 3; then compound 4; then compound 1; then compound 2.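

In this assay, going by these compounds alone, (2-hydroxypropyl)amino in place of morpholin-4-yl on a sulfonyl sulfur gives a 3.1-fold lower number from compound 1 to compound 4 (0.49 log units; beyond the scatter), a modest step and the first single change that can be read on its own. It shows that what the sulfonyl sulfur bears does affect the number, and that the ring of morpholin-4-yl is not needed to reach a low one: the open chain, which adds hydrogen-bond donors, gives the lower number of the pair. Nothing shown explains the direction or the size of this step.

The change removes the ring, places a hydrogen on the nitrogen and brings in a hydroxyl all at once, so the compounds shown do not tell which of these parts goes with the lower number. On these data alone, a plain propylamino group without the hydroxyl would separate the hydroxyl from the rest, a piperidin-1-yl ring would test the ring oxygen of morpholin-4-yl, and whether the step carries over to other substituents on the shared core also remains open.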